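Aminochromone series: hydroxy in place of chloro

This account rests on a few compounds, and the source may have more. Where it says the series, first, only, none or still open, it means among the compounds named here.

Measured compounds:
compound 1 `Nc1ccc(-c2cc(=O)c3c(N)cccc3o2)cc1` 7.3 nM
compound 2 `Nc1ccc(-c2cc(=O)c3c(N)ccc(Cl)c3o2)cc1` 9.8 nM
compound 3 `Nc1ccc(-c2cc(=O)c3c(N)c(F)cc(F)c3o2)cc1` 6 nM

All three values come from a functional assay on MCF7 cells (Homo sapiens) for inhibition, in the absence of a further agent; a higher number here means a weaker inhibitor, a lower number a stronger inhibitor. Among the measured compounds shown here, compound 2 gives the largest of the three numbers, but its gaps to compound 1 and to compound 3 both lie within the scatter, so no compound separates from the others. For the measured compounds named here, the one single-point step measured so far, a 1.3-fold higher number from compound 1 to compound 2 (0.13 log units; within the scatter), is the only comparison that bears on substitution at this position of the shared core, and it moved nothing beyond the scatter.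

Compound 4 `Nc1ccc(-c2cc(=O)c3c(N)ccc(O)c3o2)cc1` differs from compound 2 as follows: hydroxy in place of chloro on an aromatic carbon. Going by the values given here, no measured pair shows a hydroxy entering or a chloro leaving at this position, so the step from compound 2 to compound 4 has no direct precedent. What the data do show is that this position of the core tolerated a chloro in place of hydrogen without a shift beyond the scatter, and compound 3 with two fluoro groups on the same ring stays in the same band. The expectation is therefore a step of a 1.4-fold lower number from compound 2 to compound 4 (0.15 log units; within the scatter) in this assay, that is, none beyond the scatter. Compound 4 is estimated at 7 nM in this assay, with a range from 3 nM to 17 nM.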

Compound 4, half-maximal inhibitory concentration: 5300 nM
The estimate for compound 4 lay 760-fold (2.88 log units) below the measured number; the whole stated range lies below it.
By their numbers in this assay, from the lowest: compounds 3, 1 and 2 (each within the scatter of the next); then compound 4.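

In this assay this position proves far from indifferent to its substituent: hydroxy in place of chloro gives a 540-fold higher number from compound 2 to compound 4 (2.73 log units; beyond the scatter) and hydroxy in place of hydrogen gives a 730-fold higher number from compound 1 to compound 4 (2.86 log units; beyond the scatter) while chloro in place of hydrogen gave only a 1.3-fold higher number from compound 1 to compound 2 (0.13 log units; within the scatter) and stayed within the scatter. The tolerance seen with chloro on this aromatic carbon, para to an amino group, therefore does not extend to hydroxy, and the loss appears against both hydrogen and chloro, so it does not depend on chloro being the group that leaves. No measurement at hand accounts for a change of this size from a swap of one heavy atom for another, and the cause remains unassigned.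

Still open, as far as these compounds go, is whether the loss belongs to hydroxy alone or also reaches a methoxy, an amine or a carboxylic acid on the same carbon. Also open, from the compounds shown here alone, is whether a hydroxy on another carbon of this ring of the shared core would give a similar step.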